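An oxadiazole replaces a difluoropropyl group on a carbonyl carbon

The source may hold more compounds than are shown below. What is called first, only, known or untested is meant among the compounds shown, and "the series" means these compounds.

Of the compounds shown here, two sharing one core have been measured in a functional assay on isolated protein for inhibition of Glucose-dependent insulinotropic receptor (Rattus norvegicus), read by HTRF and cAMP accumulation; on this read-out lower numbers stand for smaller maximal responses and higher numbers for larger maximal responses. Compound 1 `Cc1nc(S(C)(=O)=O)ccc1Oc1ncnc(OC2CCN(C(=O)SC3CC3)CC2)c1F` gives 80%. Compound 2 `CCC(F)(F)C(=O)N1CCC(Oc2ncnc(Oc3ccc(S(C)(=O)=O)nc3C)c2F)CC1` gives 90%. Among the compounds with values here, the only step between them, a number 10 percentage points higher from compound 1 to compound 2 (within the scatter), exchanges the group on a carbonyl carbon and stays within the scatter, so the two numbers cannot be told apart; compound 2 simply shows the larger of two readings that are, in effect, equal.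

Compound 3 `Cc1nc(S(C)(=O)=O)ccc1Oc1ncnc(OC2CCN(C(=O)c3noc(C(C)C)n3)CC2)c1F` changes the same position again: 5-isopropyl-1,2,4-oxadiazol-3-yl in place of 1,1-difluoropropyl on a carbonyl carbon. Within the data shown here, the one step that bears on this, from compound 1 to compound 2, also touched the carbonyl carbon and produced no change beyond the scatter. That is thin evidence, and the entering group is of a different kind, an aromatic ring rather than an open chain, so the precedent is only loosely related. On this basis the expected step in this assay is small, a number 5 percentage points lower from compound 2 to compound 3 (within the scatter), in no firm direction. Compound 3 is therefore estimated to give 85%, with a range from 60% to 100%.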

Compound 3, largest response reached (reported as efficacy), in percent of the reference or control that the assay uses: 81%
Beside the measured number, compound 3's estimate is 4 percentage points above it, within the range that was stated.
By their numbers in this assay, from the lowest: compounds 1, 3 and 2 (each within the scatter of the next).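

In this assay, the open chain of compound 2 gives way to a larger, aromatic group carrying hydrogen-bond acceptors, yet the result is only a number 9 percentage points lower from compound 2 to compound 3 (within the scatter) and so offers no real difference. Within the data shown here, compound 3 also stands against compound 1, with a number 1 percentage points higher from compound 1 to compound 3 (within the scatter) for a group of yet another kind, so the three groups on this carbonyl carbon cannot be told apart by this read-out, even though 5-isopropyl-1,2,4-oxadiazol-3-yl is the first ring with hetero atoms seen at this place and the largest of the three by heavy-atom count. Nothing available here speaks to why such different groups give readings that cannot be separated.

What remains open is how far this position can be pushed, since no group shown moves the number beyond the scatter, and a carboxylic acid, an amine or a longer chain on the same carbonyl carbon could either match these readings or break from them. As far as these compounds go, it is also open which part of the entering group matters, for instance whether a plain phenyl ring or an oxadiazole with methyl in place of isopropyl would read the same.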